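Does a Methyl on the Ring Nitrogen Change Solubility?

A few compounds are considered here, and "the series" means these few. Any claim that something is new, unique, unknown or untested is made for them only; others in the source may bear on it.

Compound 1 `Cc1[nH]c2ccc(Cl)cc2c(=O)c1Cc1ccccc1` and compound 3 `Cc1c(Cc2ccccc2)c(=O)c2cc(Cl)ccc2n1C` share one core, and the change from compound 1 to compound 3 is methyl in place of hydrogen on an aromatic nitrogen. In a physicochemical assay for solubility, read by HPLC, at pH 7.4 (on this read-out higher numbers stand for higher solubility and lower numbers for lower solubility), compound 1 gives < 2000 nM, which is a limit of the assay rather than a number. Compound 3 gives 2000 nM in this assay. The step of a number no lower from compound 1 to compound 3 (the limit leaves the size open) cannot be sized, because of the limit of < 2000 nM in this assay, at which 1 of the 3 values shown sits.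

Compound 2 `COc1ccc2c(=O)c(Cc3ccccc3)c(C)[nH]c2c1` rests on a different core; the difference between the two cores is not broken down here. In this assay compound 2 gives 5000 nM, the higher of the two plain numbers. Compound 4 `COc1ccc2c(=O)c(Cc3ccccc3)c(C)n(C)c2c1` has not yet been measured. It differs from compound 2 by methyl in place of hydrogen on an aromatic nitrogen, the same change that turns compound 1 into compound 3, made at the same kind of place.

Going by the values given here, the step from compound 2 to compound 4 in this assay is expected to be no change at the digits printed from compound 2 to compound 4 (within the scatter), resting on the measured step of a number no lower from compound 1 to compound 3 (the limit leaves the size open), which shows only that the number did not fall. Compound 4 is therefore estimated to give about 5000 nM, most likely between 1500 nM and 15000 nM.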

Compound 4, solubility: > 20000 nM
Compound 4 was reported as a limit; the forecaster's own chance of this, stated with the estimate: 20%; middle value at least 4.0-fold (0.60 log units) away from the limit.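

On the core of compound 2, methyl in place of hydrogen on an aromatic nitrogen gives an at least 4.0-fold higher number from compound 2 to compound 4 (0.60 log units; beyond the scatter) in this assay. In this assay, going by these compounds, compound 4 gives > 20000 nM, which is a limit of the assay and not a number, so the full size of this step stays open. The number did not fall on either core, as a number no lower from compound 1 to compound 3 (the limit leaves the size open) shows for the other pair, but the two steps cannot be set against each other, so whether the change carries over in size as well as in direction remains unknown: the limit of < 2000 nM in this assay, at which 1 of the 4 values shown sits.

The compounds shown leave open how other groups on that aromatic nitrogen would behave, such as an ethyl group, a longer chain, or a chain ending in an amine or a carboxylic acid. Going by these compounds alone, with only two matched pairs, they also leave open whether the same direction would hold on further cores.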